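Swapping azido for amino on a fluorinated uridine-type core

This account rests on a few compounds, and the source may have more. Where it says the series, first, only, none or still open, it means among the compounds named here.

Compound 1 `O=c1[nH]c(=O)n([C@@H]2O[C@H](CO)[C@@H](O)[C@H]2O)c(I)c1F`: > 50000 nM (a limit)
Compound 2 `[N-]=[N+]=Nc1c(F)c(=O)[nH]c(=O)n1[C@@H]1O[C@H](CO)[C@@H](O)[C@H]1O`: 600 nM

For the measured compounds named here, in a functional assay on cells (Homo sapiens) for antiproliferative activity, read by WST assay, with a stated time of 3 days (a higher number here means a weaker inhibitor, a lower number a stronger inhibitor), compound 2 gives 600 nM, the only exact number so far. Compound 1 reads > 50000 nM, which is a limit and not a number. The two differ in one place, and the measured change there is an at least 83-fold lower number from compound 1 to compound 2 (1.92 log units; beyond the scatter). This large step is the only one that bears on the next compound.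

Compound 3 `Nc1c(F)c(=O)[nH]c(=O)n1[C@@H]1O[C@H](CO)[C@@H](O)[C@H]1O` keeps the core of compound 2 but carries amino in place of azido on an aromatic carbon. The new group has not been measured at this place, so the earlier step offers only a rough guide. It shows that the group on this carbon can shift the number far, and that compound 1, which lacks azido, lies on the weak side. Some loss is therefore expected on leaving azido, though perhaps less than that seen with iodo.

The expected change is a 13-fold higher number from compound 2 to compound 3 (1.12 log units; beyond the scatter), towards a weaker inhibitor. For compound 3 the estimated value is 8000 nM, with an expected range from 1500 nM to 50000 nM.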

Compound 3, half-maximal inhibitory concentration: 900 nM
The estimate for compound 3 lay 8.9-fold (0.95 log units) above the measured number; the measured number lies below the stated range.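

In this assay, azido proves not to be essential at this position: the step is a 1.5-fold higher number from compound 2 to compound 3 (0.18 log units; within the scatter), so the two groups cannot be told apart here, even though amino is the smaller of them. Iodo is the group that stands apart on this core, with an at least 55-fold lower number from compound 1 to compound 3 (1.74 log units; beyond the scatter), a large step in the same direction as an at least 83-fold lower number from compound 1 to compound 2 (1.92 log units; beyond the scatter). The value of compound 1 is a limit and not a number, so the true size of both these steps stays unknown: the limit of > 50000 nM in this assay, at which 1 of the 3 values shown sits.

Going by these compounds, with only iodo, azido and amino compared at this carbon, it remains open whether the activity depends on a nitrogen attached there or simply on the absence of iodo. A methylamino group, a hydroxyl group or a plain hydrogen at the same carbon could help separate these two readings, and the compounds shown say nothing about how much the fluoro group or the rest of the shared core contributes to the values.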